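The source may hold more compounds than are shown below. What is called first, only, known or untested is meant among the compounds shown, and "the series" means these compounds.

Going by the values given here, in a functional assay on A2780 cells (Homo sapiens) for antiproliferative activity (a lower number here means a stronger inhibitor, a higher number a weaker inhibitor), compound 1 `Cc1ccc2c(c1C)CN(CCCCN)CC2c1ccccc1` gives 2370 nM and compound 2 `Cc1ccc2c(c1C)CN(CCCCN(C)C)CC2c1ccccc1` gives 1860 nM as the only numbers so far. Compound 3 `CNC(=O)N1Cc2c(ccc(C)c2C)C(c2ccccc2)C1` is recorded as "not determined" (no result reported) and so offers no starting value. Compound 4 `Cc1ccc2c(c1C)CN(C(=O)N1CCCCC1)CC2c1ccccc1` differs from it by piperidin-1-yl in place of methylamino on a carbonyl carbon with piperidin-1-yl in place of methylamino on a carbonyl carbon. Among the compounds with values here, the one measured step of a 1.3-fold lower number from compound 1 to compound 2 (0.11 log units; within the scatter) lies within the scatter and sits on a saturated chain carbon, not on this carbonyl, so it sets no expected size or direction in this assay here. The expectation therefore rests loosely on compound 2 at 1860 nM with a wide margin. Compound 4 is estimated at 3000 nM with an expected range from 800 nM to 11000 nM for now.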

Compound 4, half-maximal inhibitory concentration: 2830 nM
Compound 4: the middle estimate sits 1.1-fold (0.03 log units) above what was measured, within the range that was stated.
By their numbers in this assay, from the lowest: compounds 2, 1 and 4 (each within the scatter of the next).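

In this assay, on an amine nitrogen in a ring, (piperidin-1-yl)carbonyl in place of 4-(dimethylamino)butyl gives a 1.5-fold higher number from compound 2 to compound 4 (0.18 log units; within the scatter), and in place of 4-aminobutyl it gives a 1.2-fold higher number from compound 1 to compound 4 (0.08 log units; within the scatter). This position therefore accepts a carbonyl-linked piperidin-1-yl group as well as either aminobutyl chain without a separation beyond the scatter. The step from compound 3 cannot be read, and no evidence bears on this result. From the compounds shown here alone, whether a carboxylic acid, a longer chain or an aromatic ring on this nitrogen would give a separation beyond the scatter stays open.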